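A few compounds are considered here, and "the series" means these few. Any claim that something is new, unique, unknown or untested is made for them only; others in the source may bear on it.

Measured compounds:
compound 1 `CC(=O)Nc1cc2c(C3CCN(C)CC3)c[nH]c2cn1` — in an assay for binding affinity to 5-hydroxytryptamine receptor 1D (Homo sapiens), read by radioligand binding (on this read-out higher numbers stand for weaker inhibition and lower numbers for stronger inhibition), compound 1 gives 39 nM
compound 2 `CCCCCCCC(=O)Nc1ccc2[nH]cc(C3CCN(C)CC3)c2n1` — in this assay compound 2 gives 110 nM
compound 3 `CN1CCC(c2c[nH]c3ccc(NC(=O)C4CC4)nc23)CC1` — in this assay compound 3 gives 1800 nM

Among these three numbers compound 2 holds the second highest place. Compound 1, with its acetyl amide on a differently arranged core, sits nearest to it, at a lower number that lies beyond the scatter; compound 3 sits furthest from it, at a much higher number. For the measured compounds named here, the one measured step that touches the carbonyl carbon of the amide is the step of a 16-fold higher number from compound 2 to compound 3 (1.21 log units; beyond the scatter), where cyclopropyl took the place of heptyl and the number rose sharply.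

Compound 4 `CN1CCC(c2c[nH]c3ccc(NC(=O)c4ccc(C#N)cc4)nc23)CC1` arises from compound 2 by the change (4-cyanophenyl in place of heptyl on a carbonyl carbon). Going by the values given here, no measured compound carries an aromatic group on that carbonyl carbon, so the only guide is the step from compound 2 to compound 3, which shows that leaving the heptyl chain cost binding. Compound 4 is therefore expected to give a higher number than compound 2, though the size of that rise is uncertain; the expected step is a 2.7-fold higher number from compound 2 to compound 4 (0.44 log units; beyond the scatter). For compound 4 the estimate in this assay is 300 nM, within a range from 80 nM to 1500 nM.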

Compound 4, inhibition constant: 380 nM
Compound 4: middle estimate off by 1.3-fold (0.10 log units), on the low side, within the range that was stated.
By their numbers in this assay, from the lowest: compound 1; then compound 2; then compound 4; then compound 3.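

The amide carbonyl carbon on the shared core now carries three different groups in this assay, and the result shows that an aromatic ring is accepted there. Putting 4-cyanophenyl in place of heptyl gives a 3.5-fold higher number from compound 2 to compound 4 (0.54 log units; beyond the scatter) and so still costs binding, but far less than the cyclopropyl step did. Read from the other side, 4-cyanophenyl in place of cyclopropyl gives a 4.7-fold lower number from compound 3 to compound 4 (0.68 log units; beyond the scatter) and recovers part of that loss, so among these three groups the heptyl chain gives the lowest number and cyclopropyl the highest. No evidence is available that would explain this order.

Going by these compounds, what the nitrile itself contributes remains open, and a plain phenyl on the same carbonyl carbon would separate it from the ring. Also open, on these data alone, is how the number changes along the chain, for which a butyl group at this place would give a first reading.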